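Swapping fluoro for trifluoromethyl on the shared core

A few compounds are considered here, and "the series" means these few. Any claim that something is new, unique, unknown or untested is made for them only; others in the source may bear on it.

Of the compounds shown here, three have been measured so far in an assay on HEK293 cells for inhibition of acid ceramidase (Rattus norvegicus), read by LC-MS, with a stated time of 30 min; on this read-out higher numbers stand for weaker inhibition and lower numbers for stronger inhibition. Compound 1 `CCCCCCNC(=O)n1cc(C(F)(F)F)c(=O)[nH]c1=O` gives 12 nM, and compound 2 `CCCCCCNC(=O)n1cc(F)c(=O)n(C(=O)OC)c1=O` gives 7 nM. Compound 3 `CCCCCCCCNC(=O)n1cc(F)c(=O)[nH]c1=O` gives 46 nM, the highest of the three numbers, which on this read-out means the weakest inhibition; the gap to compound 1 and the gap to compound 2 both lie beyond the usual scatter.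

The next compound, compound 4 `CCCCCCCCNC(=O)n1cc(C(F)(F)F)c(=O)[nH]c1=O`, differs from compound 3 in a single place: trifluoromethyl in place of fluoro on an aromatic carbon. For the measured compounds named here, no measured pair in this set differs in only that place, so the size of this step is not known from direct comparison. Compound 1 also carries trifluoromethyl on the shared core and sits lower than compound 3, but compounds 1 and 3 differ in more than one place, so their values alone cannot be credited to the group swap.

On that basis a modest move toward stronger inhibition is expected, with a step of about a 1.8-fold lower number from compound 3 to compound 4 (0.26 log units; within the scatter) for compound 4, which is estimated at 25 nM with a likely range from 8 nM to 80 nM.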

Compound 4, half-maximal inhibitory concentration: 7 nM
For compound 4 the middle estimate is 3.6-fold (0.55 log units) above the measured one, and the stated range ends above it.
By their numbers in this assay, from the lowest: compounds 2, 4 and 1 (each within the scatter of the next); then compound 3.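

In this assay, trifluoromethyl in place of fluoro on an aromatic carbon gives a 6.6-fold lower number from compound 3 to compound 4 (0.82 log units; beyond the scatter) with nothing else changed, so this position clearly responds to the swap when the rest of the molecule is held constant. With trifluoromethyl in that place, ethyl in place of hydrogen on a saturated chain carbon, six bonds along the chain from an amide-type nitrogen, gives a 1.7-fold lower number from compound 1 to compound 4 (0.23 log units; within the scatter) and so makes no difference that can be told from the scatter in this assay. Nothing available here explains why the swap at this position matters.

From the compounds shown here alone, whether a chloro, methyl or nitrile group on this aromatic carbon would match trifluoromethyl stays open. So does whether a longer chain than that of compound 4 would leave the number unchanged.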